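This account rests on a few compounds, and the source may have more. Where it says the series, first, only, none or still open, it means among the compounds named here.

Compound 3 `COc1cc(-c2ccnc(N)n2)cc2[nH]nc(N)c12` carries a methyl on an oxygen on an aromatic ring of the shared core. In a physicochemical assay for solubility, read by LC-MS, in phosphate buffer, measured as kinetic solubility, with a stated time of 24 h, at 25 degrees C, at pH 7.4 (on this read-out lower numbers stand for lower solubility and higher numbers for higher solubility), compound 3 gives only a limit of the assay, > 100000 nM, so its exact standing among the measured compounds cannot be read (the limit of > 100000 nM in this assay, at which 1 of the 3 values shown sits). Compound 1 `Nc1nccc(-c2cc(OC3CCOC3)c3c(N)n[nH]c3c2)n1` bears an oxolan-3-yl at the same oxygen and gives 751000 nM in this assay, while compound 2 `CC(C)Oc1cc(-c2ccnc(N)n2)cc2[nH]nc(N)c12`, with an isopropyl there, gives 354000 nM. For the measured compounds named here, the one readable step among them is a 2.1-fold lower number from compound 1 to compound 2 (0.33 log units; beyond the scatter); the steps a step that the limit leaves unreadable from compound 1 to compound 3 and a step that the limit leaves unreadable from compound 2 to compound 3 remain unreadable.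

Compound 4 `Nc1nccc(-c2cc(OC3CCCOC3)c3c(N)n[nH]c3c2)n1` is reached from compound 3 through (oxan-3-yl in place of methyl on an oxygen on an aromatic ring). The closest measured guide is the oxolan-3-yl of compound 1, a ring ether like the oxan-3-yl that enters, and its value of 751000 nM sets the expectation. Compound 4 is therefore expected to land near compound 1, at an estimated 500000 nM in this assay, with a likely range from 200000 nM to 1000000 nM. Against the limit of compound 3 this expected step reads a step that the limit leaves unreadable from compound 3 to compound 4, whose true size stays unreadable.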

Compound 4, solubility: 1000000 nM
Compound 4: middle estimate off by 2.0-fold (0.30 log units), on the low side; low and high end bracket the measured number.
By their numbers in this assay, from the lowest: compound 2; then compounds 1 and 4 (each within the scatter of the next).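

In this assay the oxan-3-yl and the oxolan-3-yl on this oxygen cannot be told apart, with a 1.3-fold higher number from compound 1 to compound 4 (0.12 log units; within the scatter). Against the isopropyl of compound 2, the oxan-3-yl gives a 2.8-fold higher number from compound 2 to compound 4 (0.45 log units; beyond the scatter), so compound 4 now joins compound 1 as a second ring ether whose number stands beyond the scatter from that of compound 2, though two such compounds show no general rule. Compound 3 still gives only a limit, so every step to or from it cannot be read: the limit of > 100000 nM in this assay, at which 1 of the 4 values shown sits.

The compounds shown leave open whether the ring or its oxygen goes with the higher numbers, which a cyclopentyl, a ring of carbon alone, on the same oxygen could separate. On these data alone, how a ring bearing an amine would read at this place also remains open.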